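Cytotoxicity notes on the pyrazole series: step to compound 3

The source may report more compounds than this note shows. Statements on the series, on what has been measured and on what is new or still open speak of the compounds shown alone.

Measured compounds:
- compound 1 `O=C(Nc1cccc(-n2cc(-c3ccncc3)c(-c3ccc(Cl)c(O)c3)n2)c1)Nc1cccc(C(F)(F)F)c1`; > 32500 nM
- compound 2 `COc1cc(-c2nn(-c3cccc(NC(=O)c4cccc(C(F)(F)F)c4)c3)cc2-c2ccncc2)ccc1Cl`; > 50000 nM

In a functional assay on SK-MEL-2 cells (Homo sapiens) for inhibition, read by sulforhodamine B assay, with a stated time of 48 h (on this read-out higher numbers stand for lower toxicity in this test and lower numbers for higher toxicity in this test), compound 1 gives > 32500 nM, which is a limit of the assay and not a number. In this assay compound 2 gives > 50000 nM, again a limit of the assay rather than a number. So compound 2 stands only at a limit, and the other value shown is a limit as well, at the level (the limit of > 32500 nM in this assay, at which 1 of the 2 values shown sits).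

Compound 3 `COc1cc(-c2nn(-c3cccc(NC(=O)Nc4ccc(Cl)c(Cl)c4)c3)cc2-c2ccncc2)ccc1Cl` differs from compound 2 by (3,4-dichlorophenyl)amino in place of 3-(trifluoromethyl)phenyl on a carbonyl carbon; cut one bond further out, this reads (3-(trifluoromethyl)phenyl)carbonyl to (3,4-dichlorophenyl)carbamoyl. Going by the values given here, no measured step of this kind exists in the set. Since both compound 1 and compound 2 sit at limits, compound 3 is expected to show no change beyond the scatter, with the step from compound 2 to compound 3 estimated as an at least 1.2-fold lower number from compound 2 to compound 3 (0.09 log units; that floor lies within the scatter). Compound 3 is thus expected at about 40000 nM, within a range of 12000 nM to 100000 nM.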

Compound 3, concentration lethal to 50% of the cells: 4850 nM
Beside the measured number, compound 3's estimate is 8.2-fold (0.92 log units) above it, and the stated range ends above it.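

Replacing 3-(trifluoromethyl)phenyl on the carbonyl carbon with (3,4-dichlorophenyl)amino gives, in this assay, an at least 10-fold lower number from compound 2 to compound 3 (1.01 log units; beyond the scatter). Going by these compounds alone, this shows that the read-out responds to a change at this position, and compound 3 is the first compound in the set with a number rather than a limit. The size of the step is only a floor, since the value of compound 2 is a limit of the assay: the limit of > 50000 nM in this assay, at which 1 of the 3 values shown sits.

The change brings in the amino nitrogen and the two chlorines at once, so the compounds shown do not separate their contributions to the step. On these data alone, it also remains open how this position would respond to a saturated amine or a carboxylic acid in place of the (3,4-dichlorophenyl)amino group.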